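Adding one methyl to the methoxymethyl group

A few compounds are considered here, and "the series" means these few. Any claim that something is new, unique, unknown or untested is made for them only; others in the source may bear on it.

- compound 1 `CC(C)(O)c1cc(-c2ccccc2)c2ccc(OCc3cccc(C4(O)CCOCC4)c3)cc2c1`: 59 nM
- compound 2 `COCc1cc(-c2ccccc2)c2ccc(OCc3cccc(C4(O)CCOCC4)c3)cc2c1`: 4 nM

In a functional assay for inhibition, with Homo sapiens as the target (on this read-out lower numbers stand for stronger inhibition and higher numbers for weaker inhibition), compound 2 gives 4 nM, the lower of the two numbers. Compound 3 `COC(C)c1cc(-c2ccccc2)c2ccc(OCc3cccc(C4(O)CCOCC4)c3)cc2c1` changes compound 2 in one place: methyl in place of hydrogen on a saturated chain carbon bound to an aromatic carbon and an oxygen on a saturated carbon. This puts methyl in place of hydrogen on a saturated chain carbon bound to an aromatic carbon and an oxygen on a saturated carbon, so methoxymethyl becomes 1-methoxyethyl.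

Going by the values given here, only one measured step bears on this, and it changes the same group: a 15-fold lower number from compound 1 to compound 2 (1.17 log units; beyond the scatter). That large step shows that the number can move strongly when this group changes, but it replaced a different group, so it cannot size this smaller edit. A small rise is therefore expected, possibly no larger than the scatter, with an estimated 2.0-fold higher number from compound 2 to compound 3 (0.30 log units; within the scatter). For compound 3 the estimate is 8 nM, with an expected range of 2 nM to 30 nM.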

Compound 3, half-maximal inhibitory concentration: 41 nM
Compound 3: middle estimate off by 5.1-fold (0.71 log units), on the low side, outside the stated range (above it).
By their numbers in this assay, from the lowest: compound 2; then compounds 3 and 1 (each within the scatter of the next).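

A single methyl on this saturated chain carbon is enough to matter: in this assay it gives a 10-fold higher number from compound 2 to compound 3 (1.01 log units; beyond the scatter), so even the smallest addition here can shift the number strongly. The other new step, a 1.4-fold lower number from compound 1 to compound 3 (0.16 log units; within the scatter), lies within the scatter, so 1-methoxyethyl and 1-hydroxy-1-methylethyl read alike, and among these three compounds the low number belongs only to compound 2, the one whose chain carbon keeps both hydrogens. Nothing available here gives a measured reason for this loss.

The compounds shown leave open whether an ethyl group or a fluorine on this carbon would move the number as the methyl does. They also leave open how an amine in place of the methoxy group would read on this chain carbon.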